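A few compounds are considered here, and "the series" means these few. Any claim that something is new, unique, unknown or untested is made for them only; others in the source may bear on it.

Measured compounds in a physicochemical assay for solubility, in phosphate buffer, at pH 6.5; on this read-out lower numbers stand for lower solubility and higher numbers for higher solubility:
- compound 1 `C=C[C@@H]1C[C@]1(NC(=O)[C@@H]1C[C@@H](Oc2nccc3cc(OC)ccc23)CN1C(=O)[C@@H](NC(=O)N[C@@H](C)COC)C(C)(C)C)C(=O)NS(=O)(=O)C1CC1`: 1070 ug/mL
- compound 2 `C=C[C@@H]1C[C@]1(NC(=O)[C@@H]1C[C@@H](Oc2nccc3cc(OC)ccc23)CN1C(=O)[C@@H](NC(=O)N[C@H](COC)C(C)(C)C)C(C)(C)C)C(=O)NS(=O)(=O)C1CC1`: 609 ug/mL
- compound 3 `C=C[C@@H]1C[C@]1(NC(=O)[C@@H]1C[C@@H](Oc2nccc3cc(OC)ccc23)CN1C(=O)[C@@H](NC(=O)N[C@H](C(=O)OC)C(C)(C)C)C(C)(C)C)C(=O)NS(=O)(=O)C1CC1`: 754 ug/mL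

Compound 1 gives the largest of the three numbers, yet a 1.8-fold lower number from compound 1 to compound 2 (0.24 log units; within the scatter) and a 1.4-fold lower number from compound 1 to compound 3 (0.15 log units; within the scatter) both lie within the scatter, and a 1.2-fold higher number from compound 2 to compound 3 (0.09 log units; within the scatter) likewise, so the three compounds are not separated by this assay.

Compound 4 `C=C[C@@H]1C[C@]1(NC(=O)[C@@H]1C[C@@H](Oc2nccc3cc(OC)ccc23)CN1C(=O)[C@@H](NC(=O)N[C@H](C(N)=O)C(C)(C)C)C(C)(C)C)C(=O)NS(=O)(=O)C1CC1` is still unmeasured. It differs from compound 1 in that (1-carbamoyl-2,2-dimethylpropyl in place of 1-(methoxymethyl)ethyl on an amide-type nitrogen). The change combines two of the measured moves: the tert-butyl for methyl exchange read across a 1.8-fold lower number from compound 1 to compound 2 (0.24 log units; within the scatter), and an exchange at the same chain carbon, read across a 1.2-fold higher number from compound 2 to compound 3 (0.09 log units; within the scatter) as methoxycarbonyl for methoxymethyl, here carried on to a carbamoyl group. Going by the values given here, neither of these steps moved the number beyond the scatter, and no measured pair contains a carbamoyl group, so the carbamoyl part of the change is uncharted. No step beyond the scatter is therefore expected in this assay; the only hint of direction is the small downward drift seen in both steps away from compound 1.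

For compound 4 the expected value is 720 ug/mL, with a range of 350 ug/mL to 1450 ug/mL. The step this estimate implies, a 1.5-fold lower number from compound 1 to compound 4 (0.17 log units; within the scatter), is expected to stay within the scatter.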

Compound 4, solubility: 557 ug/mL
Estimate against measurement, compound 4: 1.3-fold (0.11 log units) above; the measured number falls inside the stated range.
By their numbers in this assay, from the lowest: compounds 4, 2, 3 and 1 (each within the scatter of the next).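

In this assay, the new carbamoyl group on this saturated chain carbon does not separate compound 4 from any earlier compound: a 1.9-fold lower number from compound 1 to compound 4 (0.28 log units; within the scatter), a 1.1-fold lower number from compound 2 to compound 4 (0.04 log units; within the scatter) and a 1.4-fold lower number from compound 3 to compound 4 (0.13 log units; within the scatter). The full exchange brings in a hydrogen-bond donor, as 1-carbamoyl-2,2-dimethylpropyl carries one and 1-(methoxymethyl)ethyl carries none, and the amino in place of methoxy exchange on the carbonyl carbon adds a further kind of change at this position, yet all four compounds remain unresolved in this assay. Nothing available bears on the origin of these small differences.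

As far as these compounds go, whether a carboxylic acid or a primary amine on this chain carbon would give a step beyond the scatter remains open, and the present set offers no such group to test it. Also open, from the compounds shown here alone, is how the carbamoyl group reads with a methyl group or a longer chain in place of the tert-butyl group, since here it appears only within 1-carbamoyl-2,2-dimethylpropyl on the amide-type nitrogen.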